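Changing the chain end of compound 1 to make compound 4

This account rests on a few compounds, and the source may have more. Where it says the series, first, only, none or still open, it means among the compounds named here.

Compound 1 `C/N=C(/NC#N)NCCCn1nc(-c2ccccc2)ccc1=O` gives 40.5% in a functional assay on the whole organism with Rattus norvegicus as the target, at a dose of 100 mg/kg (a higher number here means more inhibition at the dose given (going by the name of the read-out), a lower number less inhibition), the second highest of the three measured numbers. Compound 2 `O=c1ccc(-c2ccccc2)nn1CCCCNC(=S)Nc1ccc(Cl)cc1` gives 43.2%, a value within the scatter of compound 1, while compound 3 `O=c1ccc(-c2ccccc2)nn1CCCNC(=S)Nc1ccccc1` gives 12.1%, which lies beyond the scatter below compound 1. Compound 4 `C/N=C(\S)NCCCCCn1nc(-c2ccccc2)ccc1=O` has not yet been measured. It differs from compound 1 by a group of 7 heavy atoms (4 carbon, 2 nitrogen, 1 sulfur; no ring) in place of a group of 7 heavy atoms (3 carbon, 4 nitrogen; no ring), on a saturated chain carbon, three bonds along the chain from an aromatic nitrogen. Among the compounds with values here, no measured pair shows this exact change, so its effect is uncertain, and the spread among compounds 1, 2 and 3 shows that nearby structures can land far apart. In this assay the step of a number 7.5 percentage points lower from compound 1 to compound 4 (within the scatter) is expected, a modest drop that need not exceed the scatter. Compound 4 is therefore estimated at 33% in this assay, with a range from 10% to 58%.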

Compound 4, a percentage reported as inhibition, in the whole organism at one dose (the size of the read-out at that dose, not a potency): 68.9%
Estimate against measurement, compound 4: 35.9 percentage points below, and the stated range ends below it.
By their numbers in this assay, from the lowest: compound 3; then compounds 1 and 2 (each within the scatter of the next); then compound 4.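

In this assay, this chain position responds strongly to what is placed there: putting the group with 4 carbon, 2 nitrogen and 1 sulfur atoms in place of the group with 3 carbon and 4 nitrogen atoms gives a number 28.4 percentage points higher from compound 1 to compound 4 (beyond the scatter). Within the data shown here, this is the first step in the set that changes only one place, and both groups hold 7 heavy atoms, so the number moved without any change in that count. No measured property accounts for the step. Going by these compounds, whether an amine or a carboxylic acid at this chain end would keep the higher number remains open. So does the effect of a longer chain.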